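The source may hold more compounds than are shown below. What is called first, only, known or untested is meant among the compounds shown, and "the series" means these compounds.

Going by the values given here, in a toxicity assay on cells (Erythrocyte, Homo sapiens) for cytotoxicity, read by hemolysis (on this read-out lower numbers stand for an effect already at smaller amounts and higher numbers for an effect only at larger amounts of compound), compound 3 `CCCCCCCCCCCCCC(=O)NCc1ccc(C(=O)N[C@@H](CCC(N)=O)C(=O)O)cc1` gives 520 ug/mL, the higher of the two numbers so far, while compound 1 `CCCCCCCCCCCCCC(=O)NCc1ccc(C(=O)N[C@H](C(=O)O)[C@@H](C)CC)cc1` gives 66 ug/mL. Compound 2 `CC/C=C/CC(=O)NCc1ccc(C(=O)N[C@H](C(=O)O)[C@@H](C)CC)cc1` reads > 1500 ug/mL, which is a limit of the assay and not a number. Compound 4 `CCCCCCCCCCCCCC(=O)NCc1ccc(C(=O)N[C@H](C(N)=O)[C@@H](C)CC)cc1` is still unmeasured. It differs from compound 3 as follows: 1-carbamoyl-2-methylbutyl in place of 3-carbamoyl-1-carboxypropyl on an amide-type nitrogen. In words, 1-carbamoyl-2-methylbutyl stands in place of 3-carbamoyl-1-carboxypropyl on an amide-type nitrogen. Among the compounds with values here, one measured step bears on this change: a 7.9-fold higher number from compound 1 to compound 3 (0.90 log units; beyond the scatter), where 2-carbamoylethyl replaced sec-butyl. Read backwards, that step suggests a move of similar size towards a lower number in this assay, although no measured step tests the loss of the carboxy part. The expected step is a 12-fold lower number from compound 3 to compound 4 (1.06 log units; beyond the scatter). Compound 4 is estimated at 45 ug/mL, with an expected range from 12 ug/mL to 170 ug/mL.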

Compound 4, half-maximal effective concentration: 100 ug/mL
For compound 4 the middle estimate is 2.2-fold (0.35 log units) below the measured one; measured number inside the range.
By their numbers in this assay, from the lowest: compounds 1 and 4 (each within the scatter of the next); then compound 3. At a limit, above all of these: compound 2.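

In this assay, amino in place of hydroxy on a carbonyl carbon gives a 1.5-fold higher number from compound 1 to compound 4 (0.18 log units; within the scatter), so this swap alone shows no difference that can be told from the scatter. Going by these compounds alone, the larger change gives a 5.2-fold lower number from compound 3 to compound 4 (0.72 log units; beyond the scatter), which makes it the first measured step to include the loss of the carboxy part. With the swap at the carbonyl carbon unreadable, that step lines up with the sec-butyl side chain shared by compound 1 and compound 4.

Nothing shown gives a cause for these steps. Also open, from the compounds shown here alone, is whether a methyl ester on that carbonyl carbon, or benzyl in place of sec-butyl, would read like compound 4.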